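The source may hold more compounds than are shown below. What is called first, only, known or untested is meant among the compounds shown, and "the series" means these compounds.

Compound 1 `Cc1cc(C(=O)O)nn1Cc1cc(Br)ccc1OCc1ccccc1` gives 1.2 in a physicochemical assay for lipophilicity, at pH 7.4 (a lower number here means a more polar compound, a higher number a more lipophilic compound), compound 2 `Cc1cc(C(=O)Nc2c(F)cccc2F)nn1Cc1cc(Cl)ccc1OCc1ccccc1` gives 3.7, and compound 3 `Cc1cc(C(=O)NN2CCOCC2)nn1Cc1cc(Cl)ccc1OCC(C)C` gives 3.1.

Compound 2 stands highest of the three numbers in this assay: compound 3 comes nearest and compound 1 lies furthest, both with lower numbers beyond the scatter. Compound 4 `Cc1cc(NC(=O)C2CCCC2)nn1Cc1cc(Cl)ccc1OCc1ccccc1` has not yet been measured. It differs from compound 2 in one place: (cyclopentylcarbonyl)amino in place of (2,6-difluorophenyl)carbamoyl on an aromatic carbon. Among the measured compounds shown here, no measured pair here shares this change, so no step of this kind is known. Even so, compound 4 is expected to give a lower number than compound 2 in this assay, by a step of a number 0.60 log units lower from compound 2 to compound 4 (beyond the scatter), beyond the scatter. The estimate for compound 4 is 3.1, with a range from 2.5 to 3.7.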

Compound 4, distribution coefficient: 3.5
Beside the measured number, compound 4's estimate is 0.40 log units below it, within the range that was stated.
By their numbers in this assay, from the lowest: compound 1; then compound 3; then compounds 4 and 2 (each within the scatter of the next).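

In this assay, among the compounds shown here, (cyclopentylcarbonyl)amino in place of (2,6-difluorophenyl)carbamoyl on this aromatic carbon gives a number 0.20 log units lower from compound 2 to compound 4 (within the scatter), the only step read at this position. The six-membered aromatic ring and both fluorine atoms leave and a five-membered non-aromatic ring enters, yet the number does not move beyond the scatter. No supporting measurement explains this result. Still open, going by these compounds, is how an amine or a longer chain on this carbon would read in this assay. Also open, on these data alone, is whether the same change would give a similar step with the other groups on the shared core.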